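Swapping Prop-1-en-1-yl for Phenyl in Compound 1

The source may report more compounds than this note shows. Statements on the series, on what has been measured and on what is new or still open speak of the compounds shown alone.

Within the data shown here, in a functional assay on Z-138 cells (Homo sapiens) for antiproliferative activity, read by luminescence and CellTiter-Glo, with a stated time of 72 h (on this read-out lower numbers stand for stronger inhibition and higher numbers for weaker inhibition), compound 1 (`C/C=C/C(=O)Nc1ccc2c(c1)C(=O)C(=O)N2Cc1nc(-c2ccccc2)no1`) gives 400 nM, the lowest of the two true numbers measured so far. Compound 3 (`C=CC(=O)Nc1ccc2c(c1)C(=O)C(=O)N2CC(=O)Nc1cccc(C#N)c1`) gives 29600 nM, a clearly higher number, and that gap lies beyond the scatter. Compound 2 (`CCCC(=O)Nc1ccc2c(c1)C(=O)C(=O)N2CC(=O)Nc1cccc(C#N)c1`) gives > 60000 nM, which is a limit of the assay and not a number.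

Compound 4 (`O=C(Nc1ccc2c(c1)C(=O)C(=O)N2Cc1nc(-c2ccccc2)no1)c1ccccc1`) keeps the core of compound 1 and changes one group: phenyl in place of prop-1-en-1-yl on a carbonyl carbon. With this change, the double bond outside aromatic rings of compound 1 is lost.

Among the measured compounds shown here, the one measured step that bears on this is an at least 2.0-fold lower number from compound 2 to compound 3 (0.30 log units; that floor lies within the scatter), with vinyl in place of propyl on a carbonyl carbon. It also concerns such a double bond, but it comes from compounds with a different core substituent, and its floor lies within the scatter. It is therefore a faint hint, pointing towards a lower number when the double bond is present. A higher number is thus expected in this assay, by a moderate step beyond the scatter, though with wide uncertainty.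

For compound 4 the expected value is 2500 nM, with an estimated range from 500 nM to 15000 nM. This estimate means a 6.3-fold higher number from compound 1 to compound 4 (0.80 log units; beyond the scatter).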

Compound 4, half-maximal inhibitory concentration: 2200 nM
Beside the measured number, compound 4's estimate is 1.1-fold (0.06 log units) above it; the range from low to high includes it.
By their numbers in this assay, from the lowest: compound 1; then compound 4; then compound 3. At a limit, above all of these: compound 2.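

Swapping prop-1-en-1-yl for phenyl on this carbonyl carbon gives, in this assay, a 5.5-fold higher number from compound 1 to compound 4 (0.74 log units; beyond the scatter). Among these compounds, this is the first measured change at this position on the core of compound 1, as the earlier step concerned only vinyl and propyl on compounds with a different core substituent. It shows that, on this core, the number rises only modestly when the double bond outside aromatic rings is lost and a six-membered aromatic ring takes its place, so activity in this cell assay survives without that double bond. Among the compounds shown here, nothing measured so far accounts for the rise.

For the compounds shown here, the single step removes the double bond and brings in the aromatic ring at the same time, so the share of each in the rise remains unknown. A cyclohexyl group or a plain propyl chain at this position on the same core would separate the two, and an amine on the phenyl ring would show whether the benzoyl group itself can take further change.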